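The compounds below may be only part of what the source reports. "The series", "measured", "known", "first", "only" and "open" are said of these compounds alone.

Measured in a functional assay on PC-3 cells (Homo sapiens) for antiproliferative activity, read by MTT assay, with a stated time of 48 h; a higher number here means a weaker inhibitor, a lower number a stronger inhibitor:
Compound 1 `CCN(CC)CCNC(=O)c1ccc(C(CC)(CC)c2ccc(OCCC(O)(CC)CC)c(C)c2)n1CC`: 3350 nM
Compound 2 `C#CCCOC(=O)c1ccc(C(CC)(CC)c2ccc(OCCC(O)(CC)CC)c(C)c2)n1CC`: > 50000 nM
Compound 3 `CCOC(=O)CN(C)C(=O)c1ccc(C(CC)(CC)c2ccc(OCCC(O)(CC)CC)c(C)c2)n1CC`: 7140 nM

Compound 2 has no exact number, only a limit: the limit of > 50000 nM in this assay, at which 1 of the 3 values shown sits. Compound 4 `CCn1c(C(=O)N(C)CC(=O)O)ccc1C(CC)(CC)c1ccc(OCCC(O)(CC)CC)c(C)c1` keeps the core of compound 2 but carries (carboxymethyl)(methyl)amino in place of (but-3-yn-1-yl)oxy on a carbonyl carbon. The closest measured change is an at least 7.0-fold lower number from compound 2 to compound 3 (0.84 log units; beyond the scatter), which brings in ((ethoxycarbonyl)methyl)(methyl)amino at that same place. Changes there also gave an at least 14-fold higher number from compound 1 to compound 2 (1.17 log units; beyond the scatter) and a 2.1-fold higher number from compound 1 to compound 3 (0.33 log units; beyond the scatter), so this position clearly matters. Within the data shown here, no compound with a carboxymethyl group has been measured, so the expectation stays loose. A lower number in this assay is expected, with an estimated at least 3.3-fold lower number from compound 2 to compound 4 (0.52 log units; beyond the scatter). The estimate for compound 4 is 15000 nM, expected between 4000 nM and 50000 nM.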

Compound 4, half-maximal inhibitory concentration: 2250 nM
Compound 4: the middle estimate sits 6.7-fold (0.82 log units) above what was measured; measured number outside the range, below it.
By their numbers in this assay, from the lowest: compounds 4 and 1 (each within the scatter of the next); then compound 3. At a limit, above all of these: compound 2.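

In this assay, hydrogen in place of ethyl, the smallest edit shown at this position, gives a 3.2-fold lower number from compound 3 to compound 4 (0.50 log units; beyond the scatter), so even the far end of the group on the carbonyl carbon counts. (Carboxymethyl)(methyl)amino brings an at least 22-fold lower number from compound 2 to compound 4 (1.34 log units; beyond the scatter), and with a 1.5-fold lower number from compound 1 to compound 4 (0.17 log units; within the scatter) it matches (2-(diethylamino)ethyl)amino, so a group ending in a carboxylic acid and one ending in an amine both serve here. The value for compound 2 is a limit, which makes its step a minimum: the limit of > 50000 nM in this assay, at which 1 of the 4 values shown sits.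

Open, going by these compounds, is how a longer chain carrying the carboxylic acid, or a plain dimethylamino group on the carbonyl carbon, would compare.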